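Amide substituent variation on the shared core, paw edema inhibition

A few compounds are considered here, and "the series" means these few. Any claim that something is new, unique, unknown or untested is made for them only; others in the source may bear on it.

For the measured compounds named here, compound 2 `COc1cc2c(cc1OC)C(CC(=O)N1CCNCC1)CC2` gives 62.5% in a functional assay on the whole organism (strain Wistar) for inhibition, with Rattus norvegicus as the target, read by paw edema, with stated times of 60 min and 1 h, at a dose of 100 mg/kg by the oral route (on this read-out higher numbers stand for more inhibition at the one dose given (going by the name of the read-out) and lower numbers for less inhibition), the higher of the two numbers known so far; compound 1 `CCCCNC(=O)CC1CCc2cc(OC)c(OC)cc21` gives 31.3%, and the step of a number 31.2 percentage points higher from compound 1 to compound 2 (beyond the scatter) is the only measured one. Compound 3 `COc1cc2c(cc1OC)C(CC(=O)N1CCOCC1)CC2` differs from compound 2 by morpholin-4-yl in place of piperazin-1-yl on a carbonyl carbon. Going by the values given here, that single measured step also changes the group on the carbonyl carbon, so a change at this place can be large, but no step tests morpholin-4-yl against piperazin-1-yl directly. For compound 3 a moderate fall is expected, a number 12.5 percentage points lower from compound 2 to compound 3 (beyond the scatter). The estimate for compound 3 is 50%, in the range 30% to 70%.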

Compound 3, a percentage reported as inhibition, in the whole organism at one dose (the size of the read-out at that dose, not a potency): 15.6%
Compound 3: the middle estimate sits 34.4 percentage points above what was measured; measured number below the stated range.
By their numbers in this assay, from the lowest: compound 3; then compound 1; then compound 2.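

On the carbonyl carbon, the identity of the ring matters and not only its presence: in this assay, two six-membered non-aromatic rings that differ in nitrogen against oxygen and in the hydrogen-bond donor of piperazin-1-yl are far apart (a number 46.9 percentage points lower from compound 2 to compound 3 (beyond the scatter)). A ring alone brings no gain here, as morpholin-4-yl also falls short of butylamino (a number 15.7 percentage points lower from compound 1 to compound 3 (beyond the scatter)). Nothing on hand accounts for these differences.

Still open, as far as these compounds go, is whether piperidin-1-yl or 4-methylpiperazin-1-yl would track compound 2 or compound 3. With only one dose shown, the order at other doses also remains open.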